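A few compounds are considered here, and "the series" means these few. Any claim that something is new, unique, unknown or untested is made for them only; others in the source may bear on it.

Three analogues built on one shared core have been measured in a functional assay on SK-MEL-28 cells (Homo sapiens) for cytotoxicity, read by MTT assay; a lower number here means a stronger inhibitor, a higher number a weaker inhibitor. Compound 1 `O=S(=O)(NCCCNc1nccc(-c2c(-c3cccc(F)c3)nc3sccn23)n1)c1cccc(F)c1` gives 8550 nM. Compound 2 `O=S(=O)(NCCNc1nccc(-c2c(-c3cccc(F)c3)nc3sccn23)n1)c1ccc(Br)cc1` gives 13500 nM in this assay. Compound 3 `O=S(=O)(NCCNc1nccc(-c2c(-c3cccc(F)c3)nc3sccn23)n1)c1ccc(F)cc1` gives 9450 nM in this assay. Compound 3 sits among these numbers without separating from either of the others: the step of a 1.1-fold higher number from compound 1 to compound 3 (0.04 log units; within the scatter) and the step of a 1.4-fold lower number from compound 2 to compound 3 (0.15 log units; within the scatter) both stay inside the scatter, as does a 1.6-fold higher number from compound 1 to compound 2 (0.20 log units; within the scatter).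

Compound 4 `Cc1ccc(S(=O)(=O)NCCNc2nccc(-c3c(-c4cccc(F)c4)nc4sccn34)n2)cc1` differs from compound 3 by methyl in place of fluoro on an aromatic carbon. The step that bears most directly on this change is a 1.4-fold lower number from compound 2 to compound 3 (0.15 log units; within the scatter), an exchange of one substituent for another on an aromatic carbon of the same six-membered ring, which left the number unchanged within the scatter. The other two steps, a 1.6-fold higher number from compound 1 to compound 2 (0.20 log units; within the scatter) and a 1.1-fold higher number from compound 1 to compound 3 (0.04 log units; within the scatter), alter the sulfonyl aryl group and the chain together, also without moving beyond the scatter. Nothing among these three compounds shows that a change on this ring shifts the number by more than the usual scatter, so no step beyond the scatter is expected in this assay in either direction. Compound 4 is therefore expected to give 9500 nM, between 4500 nM and 20000 nM. That estimate corresponds to an expected step of a 1.0-fold higher number from compound 3 to compound 4 (0.00 log units; within the scatter).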

Compound 4, half-maximal inhibitory concentration: > 20000 nM
Compound 4 gave a limit, no number; the forecaster's own chance of this, stated with the estimate: 5%; at least 2.1-fold (0.32 log units) between middle value and limit.
By their numbers in this assay, from the lowest: compounds 1, 3 and 2 (each within the scatter of the next). At a limit, above all of these: compound 4.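

In this assay compound 4 gave a limit and not a number: the limit of > 20000 nM in this assay, at which 1 of the 4 values shown sits. On this aromatic carbon, para to a large group, methyl in place of fluoro gives an at least 2.1-fold higher number from compound 3 to compound 4 (0.32 log units; beyond the scatter), whereas fluoro in place of bromo gave a 1.4-fold lower number from compound 2 to compound 3 (0.15 log units; within the scatter), so an exchange of one heavy atom for one heavy atom here can move the result past the scatter, with no hydrogen-bond donor or acceptor entering or leaving. The comparison with bromo is less firm, since an at least 1.4-fold higher number from compound 2 to compound 4 (0.17 log units; that floor lies within the scatter) does not separate methyl from bromo, while an at least 2.3-fold higher number from compound 1 to compound 4 (0.36 log units; beyond the scatter) clears the scatter in a comparison that also changes the chain and the sulfonyl aryl group.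

On these data alone, how far compound 4 lies past its limit remains unknown, so each of these steps gives only a floor and no actual size. As far as these compounds go, it is also open whether methoxy, trifluoromethyl or an amine on this aromatic carbon would behave like methyl or like fluoro, and whether the 4-methylphenyl group would give the same result on a longer chain.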